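Varying the thioether heteroaryl in a urea series

This account rests on a few compounds, and the source may have more. Where it says the series, first, only, none or still open, it means among the compounds named here.

Measured compounds:
compound 1, `CCCCCCCN(CCCCCSc1ncccn1)C(=O)Nc1ccc(F)cc1F`: 4370 nM
compound 2, `CCCCCCCN(CCCCCSc1[nH]cnc2nncc1-2)C(=O)Nc1ccc(F)cc1F`: 3310 nM

In an assay on cells (Macrophage) for inhibition of sterol O-acyltransferase 1 (Mus musculus) (on this read-out higher numbers stand for weaker inhibition and lower numbers for stronger inhibition), compound 1 gives 4370 nM and compound 2 gives 3310 nM. Compound 2 holds the lowest of the two numbers, but the step of a 1.3-fold lower number from compound 1 to compound 2 (0.12 log units; within the scatter) lies within the scatter, so the two compounds cannot be told apart on this read-out.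

Compound 3, `CCCCCCCN(CCCCCSc1n[nH]c(-c2ccccc2)n1)C(=O)Nc1ccc(F)cc1F`, has not yet been measured. It differs from compound 2 by a group of 11 heavy atoms (8 carbon, 3 nitrogen; one five-membered aromatic ring with 3 hetero atoms, one six-membered aromatic ring of carbon only) in place of a group of 9 heavy atoms (5 carbon, 4 nitrogen; one five-membered aromatic ring with 2 hetero atoms, one six-membered aromatic ring with 2 hetero atoms), on a sulfur. Among the compounds with values here, only one measured step bears on an exchange at this sulfur, a 1.3-fold lower number from compound 1 to compound 2 (0.12 log units; within the scatter), and it was within the scatter. Within the data shown here, nothing among the measured compounds carries a phenyl group on the thioether side, so no step speaks for a larger change in either direction. The expectation is therefore a number in the same range as compound 2, with the estimated step of a 1.1-fold higher number from compound 2 to compound 3 (0.02 log units; within the scatter) and no move beyond the scatter. Compound 3 is expected to give about 3500 nM in this assay, with a range from 1400 nM to 9000 nM.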

Compound 3, half-maximal inhibitory concentration: 4180 nM
Compound 3: middle estimate off by 1.2-fold (0.08 log units), on the low side; measured number inside the range.
By their numbers in this assay, from the lowest: compounds 2, 3 and 1 (each within the scatter of the next).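

In this assay, the exchange at the sulfur for 5-phenyl-1H-1,2,4-triazol-3-yl gives (a 1.3-fold higher number from compound 2 to compound 3 (0.10 log units; within the scatter)), and the direct comparison with pyrimidin-2-yl gives (a 1.0-fold lower number from compound 1 to compound 3 (0.02 log units; within the scatter)), so both steps stay within the scatter. Together with the earlier step, this means that compounds 1, 2 and 3 cannot be told apart on this read-out, even though the group on the sulfur in compound 3 adds a six-membered aromatic ring of carbon only to a five-membered aromatic ring with 3 hetero atoms. Across these three groups, the change of heteroaryl on the sulfur has not moved the number beyond the scatter, and no measurement at hand offers a reason for this flat result.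

The compounds shown leave open whether any group on this sulfur can shift the number beyond the scatter, for example a triazole whose phenyl ring is replaced by a carboxylic acid or an amine. They also leave open whether a shorter or longer saturated chain leading to the sulfur would matter more than the heteroaryl itself.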